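Chloro for methoxy on the aryl group of compound 1

A few compounds are considered here, and "the series" means these few. Any claim that something is new, unique, unknown or untested is made for them only; others in the source may bear on it.

Measured compounds:
- compound 1, `COc1ccc(-c2nc(SCC(=O)c3sc(-c4ccccc4)nc3C)[nH]c(=O)c2C#N)cc1`, in a functional assay on U-87MG ATCC cells for antiproliferative activity against U-87 MG (Homo sapiens), read by MTT assay, with a stated time of 48 h, tested at 100 uM (on this read-out higher numbers stand for a weaker effect at the one concentration tested and lower numbers for a stronger effect), compound 1 gives 1.08%
- compound 2, `COc1ccc(-c2nc(SCC(=O)c3sc(-c4ccc(Cl)cc4)nc3C)[nH]c(=O)c2C#N)cc1`, in this assay compound 2 gives 16.6%

Compound 1 holds the lowest number of the two in this assay; its nearest neighbour is compound 2, and the step of a number 15.5 percentage points higher from compound 1 to compound 2 (beyond the scatter) lies beyond the scatter.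

Compound 3, `Cc1nc(-c2ccccc2)sc1C(=O)CSc1nc(-c2ccc(Cl)cc2)c(C#N)c(=O)[nH]1`, differs from compound 1 by chloro in place of methoxy on an aromatic carbon, on an aromatic carbon of a six-membered aromatic ring of carbon only, para to a large group. Among the compounds with values here, no measured step covers this change: the one step available, a number 15.5 percentage points higher from compound 1 to compound 2 (beyond the scatter), introduces chloro in place of hydrogen on a different ring, and it moved the read-out to a weaker effect by a modest amount. That step concerns another place in the molecule, so it gives only a weak hint that chloro on an aryl ring tends toward a weaker effect here.

For compound 3 a step of a number 7.9 percentage points higher from compound 1 to compound 3 (within the scatter) is expected, a small weakening or none beyond the scatter. The estimate for compound 3 in this assay is 9%, within 0% to 30%.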

Compound 3, a percentage reported as activity, at one concentration (the size of the read-out at that concentration, not a potency): 22.5%
The estimate for compound 3 lay 13.5 percentage points below the measured number; low and high end bracket the measured number.
By their numbers in this assay, from the lowest: compound 1; then compounds 2 and 3 (each within the scatter of the next).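

In this assay, within the data shown here, the step from 4-methoxyphenyl to 4-chlorophenyl is a number 21.4 percentage points higher from compound 1 to compound 3 (beyond the scatter), the first reading at this place, on an aromatic carbon of a six-membered aromatic ring of carbon only, para to a large group. The read-out therefore responds to the group at this place, and the methoxy of compound 1 gives the stronger effect of this pair at the one concentration tested. Alongside a number 15.5 percentage points higher from compound 1 to compound 2 (beyond the scatter), two single changes that bring in chloro, each at a different place, now both move toward a weaker effect, although two steps are too few to establish a general pattern for chloro. No measurement at hand explains the step, and it cannot be assigned to the loss of methoxy or to the arrival of chloro.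

Still open, on these data alone, is whether methoxy is itself favourable at this place or chloro is unfavourable, which a plain hydrogen, fluoro, an amine, or a longer chain such as ethoxy could help separate. A single-concentration read-out also leaves open how the potencies of compound 1 and compound 3 compare.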